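Swapping the anilide aryl group on the triazole-linked chain

The compounds below may be only part of what the source reports. "The series", "measured", "known", "first", "only" and "open" are said of these compounds alone.

Measured so far:
Compound 1, `CCCCCCCCn1cc(COC2(C(F)(F)F)Oc3ccccc3C=C2C(=O)OCC)nn1`, in a functional assay on MCF7 cells (Homo sapiens) for inhibition, read by MTT assay, with a stated time of 24 h (on this read-out higher numbers stand for weaker inhibition and lower numbers for stronger inhibition), gives > 150000 nM, a limit of the assay.
Compound 2, `CCOC(=O)C1=Cc2ccccc2OC1(OCc1cn(CC(=O)Nc2ccc(OC)cc2)nn1)C(F)(F)F`, in this assay gives 28100 nM.
Compound 3, `CCOC(=O)C1=Cc2ccccc2OC1(OCc1cc(-c2ccc(Cl)cc2)no1)C(F)(F)F`, in this assay gives 18200 nM.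

Compound 2 and compound 3 give numbers in this assay that lie within the usual scatter of each other, so no order between them is claimed. Among the compounds with values here, the only value of compound 1 is a limit, described by the limit of > 150000 nM in this assay, at which 1 of the 3 values shown sits.

The unmeasured compound 4, `CCOC(=O)C1=Cc2ccccc2OC1(OCc1cn(CC(=O)Nc2ccc(I)cc2Cl)nn1)C(F)(F)F`, differs from compound 2 by 2-chloro-4-iodophenyl in place of 4-methoxyphenyl on an amide-type nitrogen. Within the data shown here, the single measured step, an at least 5.3-fold lower number from compound 1 to compound 2 (0.72 log units; beyond the scatter), concerns a different position, the chain carbon bound to the aromatic nitrogen, and gives no direct guide to exchanging one aryl group for another on the amide nitrogen. Among the measured compounds shown here, no measured pair shows such an aryl exchange. The expectation for compound 4 is therefore a step of a 1.3-fold lower number from compound 2 to compound 4 (0.11 log units; within the scatter), essentially no change beyond the scatter, with a wide range. Compound 4 is estimated at 22000 nM, between 6000 nM and 80000 nM.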

Compound 4, half-maximal inhibitory concentration: 28100 nM
Compound 4: the middle estimate sits 1.3-fold (0.11 log units) below what was measured, within the range that was stated.
By their numbers in this assay, from the lowest: compounds 3, 2 and 4 (each within the scatter of the next). At a limit, above all of these: compound 1.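

Compound 4 gives the only pair shown that exchanges one aryl group for another on the amide-type nitrogen, and in this assay the exchange leaves the number in place: no change at the digits printed from compound 2 to compound 4 (within the scatter). The (2-chloro-4-iodophenyl)carbamoyl group thus stands apart from heptyl on the saturated chain carbon bound to the aromatic nitrogen, as the (4-methoxyphenyl)carbamoyl group does: an at least 5.3-fold lower number from compound 1 to compound 4 (0.72 log units; beyond the scatter). Compound 1 is held at a limit of the assay rather than a number: the limit of > 150000 nM in this assay, at which 1 of the 4 values shown sits.

From the compounds shown here alone, it remains open whether 2-chlorophenyl or 4-iodophenyl alone would give the same number as the two halogens together. Also open, going by these compounds, is whether a carboxylic acid or an amine on that aryl ring, or a cyclohexyl group in its place, would shift the number beyond the scatter.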